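Changing the amide substituent on an adenosine-derived amide

This account rests on a few compounds, and the source may have more. Where it says the series, first, only, none or still open, it means among the compounds named here.

Of the compounds shown here, two have been measured in an assay on cell membranes for binding affinity to 2-oxoglutarate receptor 1 (Rattus norvegicus), read by radioligand binding; on this read-out higher numbers stand for weaker inhibition and lower numbers for stronger inhibition. Compound 1 `CCCCCCNC(=O)[C@H]1OC(n2cnc3c(N)ncnc32)[C@H](O)[C@@H]1O` gives 19 nM, and compound 2 `CCC(C)NC(=O)[C@H]1OC(n2cnc3c(N)ncnc32)[C@H](O)[C@@H]1O` gives 198 nM. Compound 2 therefore stands at the higher of the two numbers: the change a 10-fold higher number from compound 1 to compound 2 (1.02 log units; beyond the scatter) is beyond the scatter, so compound 2 binds more weakly than compound 1.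

Compound 3 `CC(=O)NCCNC(=O)[C@H]1OC(n2cnc3c(N)ncnc32)[C@H](O)[C@@H]1O` has not yet been measured. It differs from compound 2 in one place: 2-acetamidoethyl in place of sec-butyl on an amide-type nitrogen. Among the compounds with values here, no measured pair shows this exact change. Within the data shown here, the only step available shows that altering this substituent can move the number a great deal, as the step from compound 1 to compound 2 did. Compound 3 is expected to stay near compound 2 or to give a somewhat higher number, a step of about a 2.0-fold higher number from compound 2 to compound 3 (0.31 log units; beyond the scatter), though with wide uncertainty. The estimate for compound 3 in this assay is 400 nM, with a range from 100 nM to 2000 nM.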

Compound 3, inhibition constant: 46 nM
Beside the measured number, compound 3's estimate is 8.7-fold (0.94 log units) above it; the measured number lies below the stated range.
By their numbers in this assay, from the lowest: compound 1; then compound 3; then compound 2.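

On the amide-type nitrogen, a substituent made only of carbon is not needed for a low number: in this assay, 2-acetamidoethyl in place of sec-butyl gives a 4.3-fold lower number from compound 2 to compound 3 (0.63 log units; beyond the scatter), although the entering group carries nitrogen, oxygen and a hydrogen-bond donor and acceptor that sec-butyl lacks. Hexyl still gives the lowest number of the three: acetamido in place of butyl on the chain gives a 2.4-fold higher number from compound 1 to compound 3 (0.38 log units; beyond the scatter), so the new group improves on sec-butyl without matching the plain chain. No evidence is at hand to explain either step.

Still open, as far as these compounds go, is whether the acetamido end matters or the unbranched chain alone accounts for the drop from sec-butyl. A plain butyl chain, a 2-aminoethyl group and a chain longer than hexyl would each test a different part of that question.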